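Carbamate ester variation on the sulfamate series: compound 4

The compounds below may be only part of what the source reports. "The series", "measured", "known", "first", "only" and "open" are said of these compounds alone.

Measured so far in an assay on liver for inhibition of sterol O-acyltransferase 1 (Rattus norvegicus), using microsomes; a higher number here means a weaker inhibitor, a lower number a stronger inhibitor:
compound 1 `CCOC(=O)NS(=O)(=O)Oc1c(C(C)C)cccc1C(C)C` — > 50000 nM; > 50000 nM (2 entries)
compound 2 `CC(C)c1cccc(C(C)C)c1OS(=O)(=O)NC(=O)O[C@@H]1C[C@H](C)CCC1C(C)C` — 21000 nM
compound 3 `CC(C)c1cccc(C(C)C)c1OS(=O)(=O)NC(=O)Oc1cccnc1` — > 50000 nM

The value of compound 1 is a limit of this assay and not a number. The value of compound 3 is likewise a limit (the limit of > 50000 nM in this assay, at which 1 of the 3 values shown sits), so compound 3 stands only at the edge of what this assay reports, with a second entry that also gives no single number. Among the compounds with values here, compound 2 is the only member with a measured number. Within the data shown here, the one step measured at the ester position is an at least 2.3-fold higher number from compound 2 to compound 3 (0.37 log units; beyond the scatter), a move from a saturated ring ester to an aromatic one that went toward weaker inhibition.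

Compound 4 `CC(C)c1cccc(C(C)C)c1OS(=O)(=O)NC(=O)Oc1c(F)cccc1F` differs from compound 3 by 2,6-difluorophenyl in place of pyridin-3-yl on an oxygen next to a carbonyl group. Among the measured compounds shown here, no measured step relates an aromatic carbon ring to the pyridin-3-yl group at this position; what is known is that both the ethyl ester of compound 1 and the pyridin-3-yl ester of compound 3 sit at the limit, and that only the bulky saturated ester of compound 2 yields a number. The expectation is therefore no step beyond the scatter, an at least 1.1-fold lower number from compound 3 to compound 4 (0.04 log units; that floor lies within the scatter), with a reported limit the more likely outcome. Compound 4 is estimated at 45000 nM, in the range 12000 nM to 150000 nM.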

Compound 4, half-maximal inhibitory concentration: 65000 nM
The estimate for compound 4 lay 1.4-fold (0.16 log units) below the measured number; the range from low to high includes it.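

Within the data shown here, on an oxygen next to a carbonyl group, 2,6-difluorophenyl gives an aromatic ester with a single number in this assay: compound 4 reads 65000 nM, so compound 2 no longer stands alone as the only member with a measured value. The saturated ester keeps the stronger inhibition, with a 3.1-fold higher number from compound 2 to compound 4 (0.49 log units; beyond the scatter), and this runs in the same direction as an at least 2.3-fold higher number from compound 2 to compound 3 (0.37 log units; beyond the scatter), so both aromatic esters shown lie on the weaker side of 2-isopropyl-5-methylcyclohexyl. The step between the two aromatic esters cannot be read because compound 3 stands at a limit of the assay: the limit of > 50000 nM in this assay, at which 1 of the 4 values shown sits.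

The compounds shown leave open how far the number of compound 2, 21000 nM, can be lowered at this position, for instance with adamantyl or with a plain cyclohexyl ester lacking the isopropyl and methyl groups. They also leave open whether the fluorines of compound 4 matter at all, which a plain phenyl ester or a phenyl ester carrying an amine or a carboxylic acid would test.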